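Aryl variation on the shared core: compound 3 to compound 4

The source may report more compounds than this note shows. Statements on the series, on what has been measured and on what is new or still open speak of the compounds shown alone.

Working notes on the series. The shared core carries a trimethoxyphenyl group and a variable aryl group on an aromatic carbon. In a functional assay on A549 cells (Homo sapiens) for antiproliferative activity, read by MTT assay, with a stated time of 72 h (on this read-out lower numbers stand for stronger inhibition and higher numbers for weaker inhibition), compound 1 `COc1cc(-n2cnc3ccc(-c4cccc(N)c4)cc32)cc(OC)c1OC` gives 640 nM. Compound 2 `COc1cc(-c2ccc3ncn(-c4cc(OC)c(OC)c(OC)c4)c3c2)cc(OC)c1OC` gives a value that is a limit of this assay, > 10000 nM. Compound 3 `COc1cc(-n2cnc3ccc(-c4ccc(C(F)(F)F)cc4)cc32)cc(OC)c1OC` gives 3390 nM; among the two numbers shown it stands highest, and its nearest neighbour is compound 1, whose number is lower. For the measured compounds named here, the one measured step, a 5.3-fold higher number from compound 1 to compound 3 (0.72 log units; beyond the scatter), is the only direct comparison of aryl groups available, and it places compound 3 at the weak end of the measured range.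

Compound 4 `COc1cccc(-c2ccc3ncn(-c4cc(OC)c(OC)c(OC)c4)c3c2)c1` has not yet been measured. The change from compound 3 is 3-methoxyphenyl in place of 4-(trifluoromethyl)phenyl on an aromatic carbon. Going by the values given here, no measured step covers exactly this exchange; the step from compound 1 to compound 3 shows only that a change of the aryl substituent can move the number beyond the scatter. A return toward the number of compound 1 is a reasonable expectation, but not a full one, since 3-methoxyphenyl is neither of the two measured aryl groups.

For compound 4 the expected step is a 2.3-fold lower number from compound 3 to compound 4 (0.35 log units; beyond the scatter), toward a lower number. The estimate for compound 4 in this assay is 1500 nM, with a range from 500 nM to 5000 nM.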

Compound 4, half-maximal inhibitory concentration: 3180 nM
Compound 4: middle estimate off by 2.1-fold (0.33 log units), on the low side; the range from low to high includes it.
By their numbers in this assay, from the lowest: compound 1; then compounds 4 and 3 (each within the scatter of the next). At a limit, above all of these: compound 2.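

In this assay, exchanging the aryl group on the aromatic carbon of the shared core gives a 1.1-fold lower number from compound 3 to compound 4 (0.03 log units; within the scatter), so 3-methoxyphenyl and 4-(trifluoromethyl)phenyl cannot be told apart here despite their different substituents. The exchange of methoxy for amino on the same 3-substituted phenyl ring gives a 5.0-fold higher number from compound 1 to compound 4 (0.70 log units; beyond the scatter), which separates the identity of the substituent from its place on the ring in a way that the step from compound 1 to compound 3 could not: among compounds 1, 3 and 4, only the 3-aminophenyl group of compound 1 goes with the lower number, and moving from amino to methoxy without moving the substituent is enough to lose it. Nothing measured in the series gives a cause for either step.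

For the compounds shown here, compound 2 gives > 10000 nM, which is a limit of the assay, so no steps to it can be read. Open, going by these compounds, is whether the lower number of compound 1 depends on a free amine at that ring place or would persist with a dimethylamino group, a hydroxyl group, a carboxylic acid or an amine moved to the 4-position of the phenyl ring.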